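This account rests on a few compounds, and the source may have more. Where it says the series, first, only, none or still open, it means among the compounds named here.

Measured compounds and their values:

compound 1 `O=C1C(=O)N(CC(CO)NCCCNc2ccnc3cc(Cl)ccc23)c2ccccc21` — 85%
compound 2 `O=C1C(=O)N(CC(CO)NCCNc2ccnc3cc(Cl)ccc23)c2ccc(Cl)cc21` — 88%
compound 3 `O=C1C(=O)N(CC(CO)NCCCCNc2ccnc3cc(Cl)ccc23)c2ccc(F)cc21` — 83%

In an ADME assay on HCT-116 cells (Homo sapiens) for cytotoxicity, read by MTT assay, with a stated time of 48 h, tested at 20 uM (on this read-out higher numbers stand for a stronger effect at the one concentration tested and lower numbers for a weaker effect), compound 1 gives 85%, the second highest of the three numbers. The nearest neighbour is compound 3, whose 83% lies within the scatter of it, and the furthest is compound 2, whose 88% also lies within the scatter. Among the compounds with values here, the three measured compounds are thus indistinguishable on this read-out; no compound can be called the strongest or weakest of the set, and no step between any two of them has been worked out.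

Compound 4 `O=C1C(=O)N(CC(CO)NCCCNc2ccnc3cc(Cl)ccc23)c2ccc(F)cc21` is the next member to be read in this assay. It differs from compound 1 in one place: fluoro in place of hydrogen on an aromatic carbon. Compound 3 already carries a fluoro on the same ring of the shared core, with a different chain between the two nitrogen atoms, and its value sits within the scatter of compound 1. Within the data shown here, no step between measured compounds isolates this change, so the expectation rests on the spread of the three numbers, which is narrow.

From this the step from compound 1 to compound 4 is expected to be none beyond the scatter, a number 1 percentage points lower from compound 1 to compound 4 (within the scatter), in this assay. Compound 4 is therefore estimated at 84%, with a range of 72% to 93%.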

Compound 4, a percentage reported as inhibition, at one concentration (the size of the read-out at that concentration, not a potency): 66%
For compound 4 the middle estimate is 18 percentage points above the measured one, outside the stated range (below it).
By their numbers in this assay, from the lowest: compound 4; then compounds 3, 1 and 2 (each within the scatter of the next).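

In this assay, within the data shown here, fluoro in place of hydrogen on this aromatic carbon of the shared core gives a number 19 percentage points lower from compound 1 to compound 4 (beyond the scatter), the first step that lies beyond the scatter, so this position is not indifferent to substitution when the chain of compound 1 is present. The effect of fluoro here is not uniform across chains: compound 3, with fluoro at the same place and a different chain between the two nitrogen atoms, gives 83%, whereas compound 4 gives 66%, so the low number belongs to this combination of fluoro and chain rather than to fluoro alone. No measurement shown here offers an explanation for the step.

As far as these compounds go, it remains open whether chloro, methoxy or a nitrile at this position on the chain of compound 1 would give a similar fall, or whether the fall is particular to fluoro. Also open, from the compounds shown here alone, is what the hydrogen-to-fluoro exchange does on the longer chain of compound 3, and whether a still longer chain carrying fluoro stays with compound 3 or falls with compound 4.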